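A Chloro for Methyl Swap on a Shared Core

The source may report more compounds than this note shows. Statements on the series, on what has been measured and on what is new or still open speak of the compounds shown alone.

Compound 1, `COc1ccc(C2=Nn3c(nnc3-c3cc(Cl)cc(Cl)c3Cl)SC2)cc1`, gives 19.4% in a functional assay on the whole organism with Rattus norvegicus as the target, read by paw edema, at a dose of 50 mg/kg by the oral route; a lower number here means less inhibition, a higher number more inhibition at the dose given (going by the name of the read-out).
Compound 2, `Cc1ccc(C2=Nn3c(nnc3-c3cc(Cl)cc(Cl)c3Cl)SC2)cc1`, gives 19.4% in this assay.

Compound 2 stands level with compound 1 at the digits shown, and the one measured step, no change at the digits printed from compound 1 to compound 2 (within the scatter), lies within the scatter. Compound 3, `Clc1ccc(C2=Nn3c(nnc3-c3cc(Cl)cc(Cl)c3Cl)SC2)cc1`, differs from compound 2 by chloro in place of methyl on an aromatic carbon. That single step, a swap at the same aromatic carbon, is the only one that bears on it. Because the step of no change at the digits printed from compound 1 to compound 2 (within the scatter) was flat, compound 3 is expected to show no step beyond the scatter in this assay, an estimated a number 0.4 percentage points lower from compound 2 to compound 3 (within the scatter). Compound 3 is therefore estimated at 19%, with a range from 8% to 32%.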

Compound 3, a percentage reported as inhibition, in the whole organism at one dose (the size of the read-out at that dose, not a potency): 30.6%
The estimate for compound 3 lay 11.6 percentage points below the measured number, within the range that was stated.
By their numbers in this assay, from the lowest: compounds 1 and 2 (each within the scatter of the next); then compound 3.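

At this aromatic carbon, the substituent does matter: chloro in place of methyl gives a number 11.2 percentage points higher from compound 2 to compound 3 (beyond the scatter) and chloro in place of methoxy gives a number 11.2 percentage points higher from compound 1 to compound 3 (beyond the scatter) in this assay at the single oral dose. The flat step between the methoxy and methyl compounds therefore did not hold for every group here, and the 4-chlorophenyl compound stands apart from the other two.

Going by these compounds, whether fluoro, bromo, an amine or a carboxylic acid at this carbon would match chloro remains open. Nothing given here accounts for the rise.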